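The source may hold more compounds than are shown below. What is called first, only, known or untested is meant among the compounds shown, and "the series" means these compounds.

Compound 1 `CC[C@](C)(O)CC(=O)O[C@H](CC=C(C)C)C1=CC(=O)c2c(O)ccc(O)c2C1=O`: 30200 nM
Compound 2 `CC[C@@](C)(O)CC(=O)O[C@H](CC=C(C)C)C1=CC(=O)c2c(O)ccc(O)c2C1=O`: 17900 nM
Compound 3 `CC(C)=CC[C@@H](OC(=O)CC(C)(O)c1ccccc1)C1=CC(=O)c2c(O)ccc(O)c2C1=O`: not yet measured

Within the data shown here, in a functional assay on HeLa cells (Homo sapiens) for cytotoxicity, read by MTT assay (a lower number here means a stronger inhibitor, a higher number a weaker inhibitor), compound 2 gives 17900 nM, which lies within the scatter of the only other value, held by compound 1. Compound 3 keeps the shared core and the ester link of compound 2 and differs as follows: 1-hydroxy-1-phenylethyl in place of 1-hydroxy-1-methylpropyl on a saturated chain carbon bound to a carbonyl carbon. This puts 1-hydroxy-1-phenylethyl in place of 1-hydroxy-1-methylpropyl on a saturated chain carbon bound to a carbonyl carbon.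

Among the measured compounds shown here, the single measured step, a 1.7-fold lower number from compound 1 to compound 2 (0.23 log units; within the scatter), rests on (the fact that compounds 1 and 2 differ only in the configuration as drawn). For the measured compounds named here, it therefore reports on configuration alone, and no measured step covers an exchange of this group. With so little to go on, the expectation stays close to compound 2 at 17900 nM, with no change beyond the scatter. The expected step is a 1.2-fold lower number from compound 2 to compound 3 (0.08 log units; within the scatter), and the range is kept wide. For compound 3 the estimated value is 15000 nM, with an expected range of 6000 nM to 40000 nM.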

Compound 3, half-maximal inhibitory concentration: 85700 nM
Beside the measured number, compound 3's estimate is 5.7-fold (0.76 log units) below it, outside the stated range (above it).
By their numbers in this assay, from the lowest: compounds 2 and 1 (each within the scatter of the next); then compound 3.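

In this assay, placing 1-hydroxy-1-phenylethyl in place of 1-hydroxy-1-methylpropyl on a saturated chain carbon bound to a carbonyl carbon gives a 4.8-fold higher number from compound 2 to compound 3 (0.68 log units; beyond the scatter), and the same exchange gives a 2.8-fold higher number from compound 1 to compound 3 (0.45 log units; beyond the scatter). Among these compounds, both steps lie beyond the scatter, so this position responds to a change of group, whereas the one earlier step, a change of configuration, stayed within the scatter. Nothing available gives a reason for this weaker inhibition.

Going by these compounds, it remains open whether a cyclohexyl group at this place, which has no aromatic ring, would give a similar number to compound 3 or stay nearer compound 2. On these data alone, the 1-hydroxy-1-phenylethyl group of compound 3 has no defined stereocentre, so the role of configuration with this group also remains open.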